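This account rests on a few compounds, and the source may have more. Where it says the series, first, only, none or still open, it means among the compounds named here.

Measured compounds:
compound 1 `CCOc1cc(/C=C2\SC(=O)NC2=O)ccc1OCC1(C)CCc2c(C)c(OCC=C(C)C)c(C)c(C)c2O1` gives 54%
compound 2 `COc1cc(/C=C2\SC(=O)NC2=O)ccc1OCC1(C)CCc2c(C)c(OCC=C(C)C)c(C)c(C)c2O1` gives 54%
compound 3 `C=CCOc1c(C)c(C)c2c(c1C)CCC(C)(COc1ccc(/C=C3\SC(=O)NC3=O)cc1Br)O2` gives 105%

In a functional assay on MCF7 cells (Homo sapiens), tested at 7.5 uM (a higher number here means a weaker effect of the compound at the concentration tested, a lower number a stronger effect), compound 3 stands highest of the three numbers with 105%. Compound 1 gives 54% and compound 2 gives 54%, and the gap from each of them up to compound 3 exceeds the scatter; those two cannot be ordered against each other.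

Compound 4 `CC(C)=CCOc1c(C)c(C)c2c(c1C)CCC(C)(COc1ccc(/C=C3\SC(=O)NC3=O)cc1Br)O2` differs from compound 3 by one change: 2-methylprop-1-en-1-yl in place of vinyl on a saturated chain carbon bound to an oxygen on an aromatic ring The same difference, cut one bond further out, reads allyl to 3-methylbut-2-en-1-yl.

Within the data shown here, only one measured step exists, no change at the digits printed from compound 1 to compound 2 (within the scatter), and it lies within the scatter. It sits at the same kind of place but is a different and smaller exchange, so it bears on the present step only loosely, suggesting that a small alkyl change at such a place need not move the read-out. Compounds 1 and 2 do carry the 3-methylbut-2-en-1-yl group and lie far below compound 3, yet they differ from compound 3 in a second place as well, so their values cannot be credited to this change alone.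

The expected step in this assay is therefore a number 15 percentage points lower from compound 3 to compound 4 (beyond the scatter), downward at most modestly and possibly not beyond the scatter. Compound 4 is estimated at 90%, within 60% to 112%.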

Compound 4, a percentage reported as activity, at one concentration (the size of the read-out at that concentration, not a potency): 53%
Estimate against measurement, compound 4: 37 percentage points above, outside the stated range (below it).
By their numbers in this assay, from the lowest: compounds 4, 1 and 2 (each within the scatter of the next); then compound 3.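

In this assay, replacing allyloxy with (3-methylbut-2-en-1-yl)oxy gives a large step (a number 52 percentage points lower from compound 3 to compound 4 (beyond the scatter)), so the read-out is sensitive to this change on the shared core, which the earlier step between compounds 1 and 2 could not show. With (3-methylbut-2-en-1-yl)oxy held constant, the aromatic substituent has no effect beyond the scatter for bromo in place of methoxy (a number 1 percentage points lower from compound 2 to compound 4 (within the scatter)) or bromo in place of ethoxy (a number 1 percentage points lower from compound 1 to compound 4 (within the scatter)), so bromo does not by itself account for the high number of compound 3. No measurement shown here gives a reason for the step from allyloxy to (3-methylbut-2-en-1-yl)oxy.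

The compounds shown leave open whether the double bond is needed, as a saturated 3-methylbutyl ether would test, and whether a longer chain or a chain ending in an amine or a carboxylic acid would hold the read-out of compound 4 (53%). They also leave open whether allyloxy gives the same high number with methoxy or ethoxy on the aromatic carbon, and how the read-out at this single concentration relates to potency.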